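Sulfonamide aryl swap and cytotoxicity in the shared series

The compounds below may be only part of what the source reports. "The series", "measured", "known", "first", "only" and "open" are said of these compounds alone.

Compound 1 `CCCCCC(=O)Nc1ncc(C(Oc2ccc3cc(Br)ccc3c2)c2ccc(Cl)cc2)s1` carries a pentylcarbonyl amide on the shared core. In an ADME assay on HepG2 2.2.15 cells (Homo sapiens) for cytotoxicity (on this read-out lower numbers stand for higher toxicity in this test and higher numbers for lower toxicity in this test), compound 1 reaches only the limit of the test, > 50000 nM. Compound 2 `O=C(Nc1ncc(C(Oc2ccc3cc(Br)ccc3c2)c2ccc(Cl)cc2)s1)c1ccc(F)cc1` carries a different amide on the same nitrogen, and in this assay compound 2 is recorded as "not toxic" (no number reported), with no number given. Compound 3 `CCc1ccc(S(=O)(=O)Nc2ncc(C(Oc3ccc4cc(Br)ccc4c3)c3ccc(Cl)cc3)s2)cc1` carries a (4-ethylphenyl)sulfonyl on that nitrogen. In this assay compound 3 likewise gives only the limit, > 50000 nM. Compound 3 thus stands at the limit of > 50000 nM in this assay, at which 2 of the 3 values shown sit, with no number that would place it against the others. The step that the two limits leave unreadable from compound 1 to compound 3 is unreadable.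

Compound 4 `O=S(=O)(Nc1ncc(C(Oc2ccc3cc(Br)ccc3c2)c2ccc(Cl)cc2)s1)c1ccc2c(c1)CCO2` differs from compound 3 by a group of 9 heavy atoms (8 carbon, 1 oxygen; one five-membered non-aromatic ring with 1 hetero atom, one six-membered aromatic ring of carbon only) in place of a group of 8 heavy atoms (8 carbon; one six-membered aromatic ring of carbon only), on a sulfonyl sulfur. No measured step bears on this change with a readable size, and none of the three entries shown reaches a number. Within the data shown here, the only related step, a step that the two limits leave unreadable from compound 1 to compound 3, gives neither direction nor size. Compound 4 is therefore expected to stay at the limit as well, a step that the limit leaves unreadable from compound 3 to compound 4 within the scatter. The estimate for compound 4 in this assay is 60000 nM, with a range from 30000 nM to 120000 nM, most likely reported again only as a limit.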

Compound 4, half-maximal cytotoxic concentration: > 50000 nM
Compound 4: only a limit was reported; the forecaster's own chance of this, stated with the estimate: 80%; the middle value is on the limit's open side.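

In this assay, among these compounds, compound 4 gives only a limit, > 50000 nM, so no step among compound 1, compound 3 and compound 4 can be read. The values gather at one point: the limit of > 50000 nM in this assay, at which 3 of the 4 values shown sit.

The compounds shown leave open whether any group on that nitrogen gives a numerical cytotoxic concentration in this assay, and how far such values would differ.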